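From Dichlorophenyl to Pyridin-2-yl on a Shared Core

The compounds below may be only part of what the source reports. "The series", "measured", "known", "first", "only" and "open" are said of these compounds alone.

In a functional assay on MCF7 cells (Homo sapiens) for antiproliferative activity, read by MTT assay, with a stated time of 48 h (a lower number here means a stronger inhibitor, a higher number a weaker inhibitor), compound 1 (`COc1cccc(N2CCN(C(=O)/C=C/c3ccc(O)c(O)c3)CC2)c1`) gives 0.92 ug/mL, and compound 2 (`O=C(/C=C/c1ccc(O)c(O)c1)N1CCN(c2ccc(Cl)c(Cl)c2)CC1`) gives 1.28 ug/mL. Going by the values given here, these two numbers lie within the scatter of each other, so compound 2 stands level with the only other measured compound.

The next compound to consider is compound 3 (`O=C(/C=C/c1ccc(O)c(O)c1)N1CCN(c2ccccn2)CC1`), which keeps the shared core and changes one group. The change is pyridin-2-yl in place of 3,4-dichlorophenyl on an amine nitrogen in a ring. In plain terms, pyridin-2-yl takes the place of 3,4-dichlorophenyl on an amine nitrogen in a ring.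

Among the compounds with values here, one measured step bears on this change, a swap at the same place: a 1.4-fold higher number from compound 1 to compound 2 (0.14 log units; within the scatter). That step stays within the scatter, so two different groups at this place gave numbers that cannot be told apart. Within the data shown here, no measured compound carries pyridin-2-yl there, so the evidence is thin. Among the measured compounds shown here, with only that step as a guide, no change beyond the scatter is expected in this assay, in either direction.

The estimate amounts to an expected 1.1-fold lower number from compound 2 to compound 3 (0.03 log units; within the scatter). For compound 3 the expected value is 1.2 ug/mL, with an estimated range of 0.5 ug/mL to 3 ug/mL.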

Compound 3, half-maximal inhibitory concentration: 1.82 ug/mL
Compound 3: the middle estimate sits 1.5-fold (0.18 log units) below what was measured, within the range that was stated.
By their numbers in this assay, from the lowest: compounds 1, 2 and 3 (each within the scatter of the next).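

In this assay the swap to pyridin-2-yl gives a 1.4-fold higher number from compound 2 to compound 3 (0.15 log units; within the scatter) and, measured against the methoxy-bearing compound, a 2.0-fold higher number from compound 1 to compound 3 (0.30 log units; within the scatter), so both steps stay within the scatter. The position on the amine nitrogen in the ring has now held three different groups whose numbers cannot be told apart, and one of them, pyridin-2-yl, has a ring with a hetero atom and a hydrogen-bond acceptor, where 3,4-dichlorophenyl has a ring of carbon only and no acceptor. That exchange of ring type, with the loss of both chlorine atoms, thus brings no change that this assay can resolve, although nothing measured alongside these numbers speaks to the reason for that.

All three groups at this place are six-membered aromatic rings, so the compounds shown leave open how a non-aromatic group there, such as a cyclohexyl ring or a short alkyl chain, would read. They also leave open whether a phenyl ring carrying a carboxylic acid or an amine would stay level with these three.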